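Moving the hydroxyl one carbon inward on the propyl chain

This account rests on a few compounds, and the source may have more. Where it says the series, first, only, none or still open, it means among the compounds named here.

Compound 3 `N#Cc1ccc(Nc2nccc(N(CCCO)c3c(F)cc(-c4ccc(C#N)cc4)cc3F)n2)cc1` sits lowest of the three measured values in an ADME assay on MT4 cells (Homo sapiens) for cytotoxicity, read by MTT assay, with a stated time of 5 days (on this read-out higher numbers stand for lower toxicity in this test and lower numbers for higher toxicity in this test), where compound 3 gives 68000 nM. Compound 1 `CCCN(c1ccnc(Nc2ccc(C#N)cc2)n1)c1c(F)cc(-c2ccc(C#N)cc2)cc1F` gives 212000 nM and compound 2 `CCC(C)N(c1ccnc(Nc2ccc(C#N)cc2)n1)c1c(F)cc(-c2ccc(C#N)cc2)cc1F` gives 217000 nM, so both stand higher, a 3.1-fold lower number from compound 1 to compound 3 (0.49 log units; beyond the scatter) and a 3.2-fold lower number from compound 2 to compound 3 (0.50 log units; beyond the scatter), while a 1.0-fold higher number from compound 1 to compound 2 (0.01 log units; within the scatter). Compound 4 `CC(O)CN(c1ccnc(Nc2ccc(C#N)cc2)n1)c1c(F)cc(-c2ccc(C#N)cc2)cc1F` keeps the hydroxyl of compound 3 but carries 1-hydroxyethyl in place of 2-hydroxyethyl on a saturated chain carbon bound to a nitrogen on an aromatic ring. Going by the values given here, the hydroxy itself drove the lower numbers of compound 3, and a methyl on the chain carbon bound to the ring nitrogen mattered little between compound 1 and compound 2; no step in this set tests relocating the hydroxyl. The step is therefore expected to stay within the scatter, a 1.2-fold higher number from compound 3 to compound 4 (0.07 log units; within the scatter). Compound 4 is estimated at 80000 nM, with a range from 35000 nM to 180000 nM.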

Compound 4, half-maximal cytotoxic concentration: 9800 nM
For compound 4 the middle estimate is 8.2-fold (0.91 log units) above the measured one; the measured number lies below the stated range.
By their numbers in this assay, from the lowest: compound 4; then compound 3; then compounds 1 and 2 (each within the scatter of the next).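

In this assay, the place of the hydroxyl on the chain proves to count on its own: 3-hydroxypropyl to 2-hydroxypropyl, with the same atoms joined differently, gives a clear drop (a 6.9-fold lower number from compound 3 to compound 4 (0.84 log units; beyond the scatter)). Set against the chains without a hydroxyl, the 2-hydroxypropyl group stands out further (a 22-fold lower number from compound 1 to compound 4 (1.34 log units; beyond the scatter); a 22-fold lower number from compound 2 to compound 4 (1.35 log units; beyond the scatter)), with large steps from both. Nothing available here accounts for this sensitivity. Still open, going by these compounds, is whether an amine at that chain carbon would read like the hydroxyl, and how a longer chain carrying the hydroxyl would behave.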